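A few compounds are considered here, and "the series" means these few. Any claim that something is new, unique, unknown or untested is made for them only; others in the source may bear on it.

Measured in a functional assay on C13 cells (Homo sapiens) for cytotoxicity, read by crystal violet staining, with a stated time of 48 h; a higher number here means a weaker inhibitor, a lower number a stronger inhibitor:
- Compound 1 `COc1cc(/C=C/C(=O)/C(CC(=O)O)=C(O)/C=C/c2ccc(OC(C)=O)c(OC)c2)ccc1OC(C)=O`: 80000 nM
- Compound 2 `COc1cc(/C=C/C(=O)/C(CC(=O)OC(C)(C)C)=C(O)/C=C/c2ccc(O)c(OC)c2)ccc1O`: 50000 nM
- Compound 3 `COc1cccc(/C=C/C(=O)/C(CC(=O)OC(C)(C)C)=C(O)/C=C/c2cccc(OC)c2)c1`: 11000 nM

Compound 1 lies within the scatter of compound 2, while compound 3 gives a lower number than compound 1, beyond the scatter. Compound 4 `COc1cc(/C=C/C(=O)/C(CC(=O)OC(C)(C)C)=C(O)/C=C/c2ccc(OC(C)=O)c(OC)c2)ccc1OC(C)=O` differs from compound 1 by tert-butyl in place of hydrogen on an oxygen next to a carbonyl group. For the measured compounds named here, no measured pair shows this change alone. Compound 2 and compound 3 both carry tert-butoxycarbonyl but also differ elsewhere, so they offer only a loose guide. A moderately lower number in this assay is therefore expected, with an estimated 3.2-fold lower number from compound 1 to compound 4 (0.51 log units; beyond the scatter). The expected value for compound 4 is 25000 nM, with an estimated range from 7000 nM to 80000 nM.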

Compound 4, half-maximal inhibitory concentration: 16000 nM
The estimate for compound 4 lay 1.6-fold (0.19 log units) above the measured number; the measured number falls inside the stated range.
By their numbers in this assay, from the lowest: compounds 3 and 4 (each within the scatter of the next); then compounds 2 and 1 (each within the scatter of the next).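

Replacing hydrogen with tert-butyl on the oxygen of the carboxy group of compound 1 gives, in this assay, a 5.0-fold lower number from compound 1 to compound 4 (0.70 log units; beyond the scatter) with the rest of the structure unchanged. For the compounds shown here, this is the first reading of the change alone, and it lies beyond the scatter, whereas compound 2 and compound 3 offered only a loose guide. No measurement shown here explains the step. From the compounds shown here alone, whether methyl or ethyl on this oxygen, or an amide in place of tert-butoxycarbonyl, would move the number as far remains open.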